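Carbamate to urea on a shared sulfonamide core

A few compounds are considered here, and "the series" means these few. Any claim that something is new, unique, unknown or untested is made for them only; others in the source may bear on it.

In a functional assay on P388D1 cells (Mus musculus) for antiproliferative activity, read by MTT assay (a lower number here means a stronger inhibitor, a higher number a weaker inhibitor), compound 1 `COC(=O)N1CCCc2cc(S(=O)(=O)N3CC(c4ccccc4)NC3=O)ccc21` gives 2260 nM, the second highest of the three numbers measured. Compound 2 `CCCCOC(=O)N1CCCc2cc(S(=O)(=O)N3CC(c4ccccc4)NC3=O)ccc21` gives 2080 nM, and compound 3 `O=C(c1ccccc1)N1CCCc2cc(S(=O)(=O)N3CC(c4ccccc4)NC3=O)ccc21` gives 5340 nM. The two steps that start from compound 1 read differently: a 1.1-fold lower number from compound 1 to compound 2 (0.04 log units; within the scatter), whereas a 2.4-fold higher number from compound 1 to compound 3 (0.37 log units; beyond the scatter), and in the same sense a 2.6-fold higher number from compound 2 to compound 3 (0.41 log units; beyond the scatter). Compound 4 `NC(=O)N1CCCc2cc(S(=O)(=O)N3CC(c4ccccc4)NC3=O)ccc21` differs from compound 1 by amino in place of methoxy on a carbonyl carbon. Among the compounds with values here, none of the measured steps makes this exact change on the carbonyl carbon; lengthening the chain on the oxygen in compound 2 stays within the scatter, and only the phenyl of compound 3 moves the number, and then modestly. Within the data shown here, with nothing among the measured steps speaking for a large shift, compound 4 is expected to differ from compound 1 by a 1.2-fold higher number from compound 1 to compound 4 (0.06 log units; within the scatter), a step that may well not exceed the scatter. Compound 4 is therefore estimated at 2600 nM, within a range from 1200 nM to 6000 nM.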

Compound 4, half-maximal inhibitory concentration: 12300 nM
Estimate against measurement, compound 4: 4.7-fold (0.67 log units) below; the measured number lies above the stated range.
By their numbers in this assay, from the lowest: compounds 2 and 1 (each within the scatter of the next); then compound 3; then compound 4.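

At this carbonyl carbon, amino gives the widest steps seen so far in this assay, with a 5.4-fold higher number from compound 1 to compound 4 (0.74 log units; beyond the scatter) and with a 5.9-fold higher number from compound 2 to compound 4 (0.77 log units; beyond the scatter) as well. The earlier compounds shown here showed that lengthening the chain on the oxygen left the number within the scatter and that phenyl moved it only modestly, but amino goes further than phenyl, with a 2.3-fold higher number from compound 3 to compound 4 (0.36 log units; beyond the scatter) on top of the change that phenyl brought. The data shown offer no measurement that accounts for this step.

As far as these compounds go, what stays open is whether the rise follows from the amide-type hydrogens that amino brings or from the loss of the oxygen-linked chain. A methylamino or dimethylamino group on the same carbonyl carbon would bear on that question, and an aminoethyl chain would extend it.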